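Two pyrazolyl enone anilines at a single low concentration

A few compounds are considered here, and "the series" means these few. Any claim that something is new, unique, unknown or untested is made for them only; others in the source may bear on it.

Measured so far:
- compound 1 `COc1ccc(-c2cc(/C=C/C(=O)c3ccc(N)cc3)[nH]n2)cc1`: 97%
- compound 2 `COc1cc(-c2cc(/C=C/C(=O)c3ccc(N)cc3)[nH]n2)cc(OC)c1OC`: 93%

Both compounds were tested in a functional assay on COLO 205 cells (Homo sapiens) for cytotoxicity, read by sulforhodamine B assay, with a stated time of 48 h, tested at 0.01 uM; a lower number here means a stronger effect, a higher number a weaker effect of the compound at the concentration tested. At this concentration compound 1 gives 97%, and compound 2 gives 93%, so neither shows more than a small effect here. Compound 2 holds the lowest of the two numbers; its nearest neighbour is compound 1, whose number is higher by an amount that lies within the scatter of repeated runs, so no order between the two can be claimed. Among the compounds with values here, no step between measured compounds that differ in one place is available in this set.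

Compound 3 `COc1ccc(-c2cc(/C=C/C(=O)c3ccc(N)cc3)[nH]n2)cc1OC` is the next member and has not yet been measured in this assay. Compared with compound 2 it differs as follows:

hydrogen in place of methoxy on an aromatic carbon

Within the data shown here, with only two measured numbers, both high and within the scatter of each other, there is no basis for expecting a step of any size in this assay; the step from compound 2 to compound 3 is expected to stay within the scatter, as a number 2 percentage points higher from compound 2 to compound 3 (within the scatter). Compound 3 is accordingly estimated at 95%, between 85% and 100%.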

Compound 3, a percentage reported as activity, at one concentration (the size of the read-out at that concentration, not a potency): 92%
Beside the measured number, compound 3's estimate is 3 percentage points above it; the measured number falls inside the stated range.
By their numbers in this assay, from the lowest: compounds 3, 2 and 1 (each within the scatter of the next).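

Within the data shown here, the replacement of methoxy by hydrogen on an aromatic carbon, ortho to a methoxy group and meta to a large group, gives the first one-place comparison: in this assay there is a number 1 percentage points lower from compound 2 to compound 3 (within the scatter) for this change. The reverse kind of change, methoxy in place of hydrogen on an aromatic carbon, gives a number 5 percentage points lower from compound 1 to compound 3 (within the scatter) in this assay, so neither one-place step separates the compounds at this single low concentration. No measurement is available that could account for these steps.

All three numbers lie close to one another, so these steps do not show whether a methoxy group at either place matters under conditions where the compounds have a clearer effect. Also open, going by these compounds, is what a hydroxy group, a chlorine atom or a longer alkoxy chain would give on the same six-membered aromatic ring of carbon only, and what an amide in place of the aniline amine would give on the core of compound 3.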